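A few compounds are considered here, and "the series" means these few. Any claim that something is new, unique, unknown or untested is made for them only; others in the source may bear on it.

Compound 1 `O=C(CCl)Nc1ccc(C(=O)/C=C/c2ccc(F)cc2)cc1` and compound 2 `O=C(CCl)Nc1ccc(C(=O)/C=C/c2ccccc2Cl)cc1` share one core, and compound 2 differs from compound 1 by 2-chlorophenyl in place of 4-fluorophenyl on a double-bonded chain carbon bound to a double-bonded chain carbon. In a functional assay on MCF7 cells (Homo sapiens) for cytotoxicity, read by MTT assay, with a stated time of 72 h (on this read-out lower numbers stand for stronger inhibition and higher numbers for weaker inhibition), compound 1 gives 5470 nM, while compound 2 gives 5260 nM, so that the step of a 1.0-fold lower number from compound 1 to compound 2 (0.02 log units; within the scatter). Compound 3 `O=C(CSC(=S)N[C@H]1CCOC1=O)Nc1ccc(C(=O)/C=C/c2ccc(F)cc2)cc1` rests on a second core, which differs from the core of compound 1 by a group of 10 heavy atoms (5 carbon, 1 nitrogen, 2 oxygen, 2 sulfur; one five-membered non-aromatic ring with 1 hetero atom) in place of one chlorine atom, on a saturated chain carbon bound to a carbonyl carbon; in this assay compound 3 gives 83700 nM, and the step of a 15-fold higher number from compound 1 to compound 3 (1.18 log units; beyond the scatter). Compound 4 `O=C(CSC(=S)N[C@H]1CCOC1=O)Nc1ccc(C(=O)/C=C/c2ccccc2Cl)cc1` is reached from compound 3 by the same change that turns compound 1 into compound 2, namely (2-chlorophenyl in place of 4-fluorophenyl on a double-bonded chain carbon bound to a double-bonded chain carbon), a change that occurs twice among these four compounds and sits at exactly the same kind of place each time. For compound 4 a step of much the same size is expected, a 1.0-fold lower number from compound 3 to compound 4 (0.02 log units; within the scatter), because the earlier step of a 1.0-fold lower number from compound 1 to compound 2 (0.02 log units; within the scatter) stayed within the scatter and nothing among these compounds shows the second core reacting to this change differently from the first. Compound 4 is therefore expected to give about 80000 nM in this assay, most likely between 35000 nM and 180000 nM.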

Compound 4, half-maximal inhibitory concentration: 5570 nM
The estimate for compound 4 lay 14-fold (1.16 log units) above the measured number; the whole stated range lies above it.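

In this assay, the swap of 4-fluorophenyl for 2-chlorophenyl does not carry over unchanged from one core to the other, since on the second core it gives a 15-fold lower number from compound 3 to compound 4 (1.18 log units; beyond the scatter), and the two steps disagree: the same change on two cores in this assay, a 1.0-fold lower number (0.02 log units; within the scatter) from compound 1 to compound 2 and a 15-fold lower number (1.18 log units; beyond the scatter) from compound 3 to compound 4, 14-fold (1.16 log units) apart, beyond the scatter of two such steps

Read the other way, replacing the chlorine on the saturated chain carbon with the larger group gives a 1.1-fold higher number from compound 2 to compound 4 (0.02 log units; within the scatter), which does not match the step made with 4-fluorophenyl in place: the same change on two cores in this assay, a 15-fold higher number (1.18 log units; beyond the scatter) from compound 1 to compound 3 and a 1.1-fold higher number (0.02 log units; within the scatter) from compound 2 to compound 4, 14-fold (1.16 log units) apart, beyond the scatter of two such steps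

So in these four compounds the two changes do not act independently, but this rests on a single set of compounds in one assay and shows neither why they interact nor that the same would hold elsewhere in the series.

The compounds shown leave open whether another aryl group, such as unsubstituted phenyl or 4-chlorophenyl, would behave like 4-fluorophenyl or like 2-chlorophenyl on the second core. They also leave open how a smaller group in place of the chlorine, such as an amine, would respond to the same swap.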